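The source may report more compounds than this note shows. Statements on the series, on what has been measured and on what is new or still open speak of the compounds shown alone.

Two members of the series carry numbers in a functional assay on DU-145 cells (Homo sapiens) for inhibition, read by MTT assay, with a stated time of 24 h; a lower number here means a stronger inhibitor, a higher number a weaker inhibitor. Compound 1 `CCOC(=O)C1=Cc2ccccc2OC1(OCc1cn(CC(=O)Nc2ccccc2Br)nn1)C(F)(F)F` reaches only a limit of the assay there, > 150000 nM; it sits at the limit of > 150000 nM in this assay, at which 1 of the 2 values shown sits. Compound 2 `CCOC(=O)C1=Cc2ccccc2OC1(OCc1cn(-c2ccc(F)c(Cl)c2)nn1)C(F)(F)F` gives 21500 nM in this assay. Within the data shown here, the step of an at least 6.9-fold lower number from compound 1 to compound 2 (0.84 log units; beyond the scatter) is the one measured step. Among the measured compounds shown here, compound 2 thus holds the only full number in this assay, the remaining value being a limit. Compound 3 `CCOC(=O)C1=Cc2ccccc2OC1(OCc1cn(-c2ccc([N+](=O)[O-])cc2)nn1)C(F)(F)F` is not yet measured; it differs from compound 2 in 4-nitrophenyl in place of 3-chloro-4-fluorophenyl on an aromatic nitrogen. For the measured compounds named here, the single measured step replaces ((2-bromophenyl)carbamoyl)methyl with 3-chloro-4-fluorophenyl on the aromatic nitrogen, whereas compound 3 exchanges one ring for another at that same nitrogen, so no measured step bears directly on this change. No step beyond the scatter is therefore expected, and for compound 3 the step of a 1.0-fold higher number from compound 2 to compound 3 (0.01 log units; within the scatter) is estimated. Compound 3 is expected to give 22000 nM in this assay, within 7000 nM to 70000 nM.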

Compound 3, half-maximal inhibitory concentration: > 150000 nM
Compound 3: only a limit was reported (the forecaster's own chance of this, stated with the estimate: 15%); middle value at least 6.8-fold (0.83 log units) away from the limit.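

In this assay, the aromatic ring on this nitrogen is not interchangeable: 4-nitrophenyl in place of 3-chloro-4-fluorophenyl brings an at least 6.9-fold higher number from compound 2 to compound 3 (0.84 log units; beyond the scatter). The earlier step exchanged a ((2-bromophenyl)carbamoyl)methyl group for a ring set directly on the nitrogen, which left open whether any such ring would serve; compound 3 shows that the ring's substituents matter and that a directly attached ring alone does not secure a full number. The step from compound 1 to compound 3 cannot be read, and compound 2 remains the only member with a full number: the limit of > 150000 nM in this assay, at which 2 of the 3 values shown sit.

The compounds shown do not separate the contributions of the chlorine, the fluorine and the nitro group, since each ring differs from the other in more than one substituent. A phenyl ring carrying only chlorine or only fluorine, or a 4-aminophenyl or 4-carboxyphenyl group on the same nitrogen, would bear on that question.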